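Swapping the aryl group on a shared core against protein disulfide-isomerase

The source may hold more compounds than are shown below. What is called first, only, known or untested is meant among the compounds shown, and "the series" means these compounds.

Measured compounds:
compound 1, `Oc1cc2c(cc1C(c1ccc(F)cc1)N1CCCCC1)OCCO2`, 670 nM in an assay for inhibition of protein disulfide-isomerase (Homo sapiens), with a stated time of 1 h; on this read-out higher numbers stand for weaker inhibition and lower numbers for stronger inhibition
compound 2, `CCc1ccc(C(Nc2ccccn2)c2ccc3cccnc3c2O)cc1`, 170 nM in this assay
compound 3, `Cc1ccnc(NC(c2ccc3cccnc3c2O)c2c(Cl)cccc2Cl)c1`, > 40000 nM in this assay

Compound 3 sits at the weak end of these values. Its result in this assay is a limit of the assay rather than a number, as noted in the limit of > 40000 nM in this assay, at which 1 of the 3 values shown sits. Compound 4, `CCc1ccc(C(Nc2cc(C)ccn2)c2ccc3cccnc3c2O)cc1`, has not yet been measured. It differs from compound 3 by 4-ethylphenyl in place of 2,6-dichlorophenyl on a saturated chain carbon bound to an aromatic carbon and a nitrogen on an aromatic ring. Compound 2, which also carries the 4-ethylphenyl group, gives 170 nM in this assay. On that basis compound 4 is expected to be a markedly stronger inhibitor, the step of an at least 160-fold lower number from compound 3 to compound 4 (2.20 log units; beyond the scatter) being large and toward lower values. The estimate for compound 4 in this assay is 250 nM, within 80 nM to 1000 nM.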

Compound 4, half-maximal inhibitory concentration: 5390 nM
For compound 4 the middle estimate is 22-fold (1.33 log units) below the measured one, outside the stated range (above it).
By their numbers in this assay, from the lowest: compound 2; then compound 1; then compound 4. At a limit, above all of these: compound 3.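

Compound 3 has no number in this assay, only a limit of the assay: the limit of > 40000 nM in this assay, at which 1 of the 4 values shown sits. Even so, 4-ethylphenyl in place of 2,6-dichlorophenyl gives an at least 7.4-fold lower number from compound 3 to compound 4 (0.87 log units; beyond the scatter), so this change on the saturated chain carbon brings the value back into the measurable range. The 4-ethylphenyl group alone does not settle the value, however: methyl in place of hydrogen on an aromatic carbon gives a 32-fold higher number from compound 2 to compound 4 (1.50 log units; beyond the scatter).

On these data alone, it remains open whether a methoxy group or an amine on that aromatic carbon would behave like hydrogen or like methyl. As far as these compounds go, it is also open how 2,6-dichlorophenyl would read out with hydrogen there.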